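A few compounds are considered here, and "the series" means these few. Any claim that something is new, unique, unknown or untested is made for them only; others in the source may bear on it.

In an ADME assay on PBMC cells (Homo sapiens) for cytotoxicity (on this read-out lower numbers stand for higher toxicity in this test and higher numbers for lower toxicity in this test), compound 1 `COC(=O)c1cccc(OC(c2ccc(C(F)(F)F)cc2)C2CCN(C(C)CCNC(=O)c3c(Cl)cncc3Cl)CC2)n1` gives 14600 nM, the lowest of the three numbers in hand. Compound 3 `CC(CCNC(=O)c1c(Cl)cncc1Cl)N1CCC(C(Oc2ccccn2)c2ccc(Br)cc2)CC1` gives 33700 nM in this assay, and compound 2 `CCO/N=C(/c1ccc(Br)cc1)C1CCN(C(C)(C)CCNC(=O)c2c(Cl)cncc2Cl)CC1` gives 34000 nM; both of those numbers sit beyond the scatter away from compound 1. Compound 4 `CC(CCNC(=O)c1c(Cl)cncc1Cl)N1CCC(C(Oc2cccc(Cl)c2)c2ccc(C(F)(F)F)cc2)CC1` has not yet been measured in this assay. It differs from compound 1 in one place: 3-chlorophenyl in place of 6-(methoxycarbonyl)pyridin-2-yl on an oxygen on a saturated carbon. Within the data shown here, no measured pair shows this same change, so the data give no direct guide to its effect. A step of modest size is expected, probably not clearly beyond the scatter and, if anything, toward a lower number, amounting to a 1.3-fold lower number from compound 1 to compound 4 (0.12 log units; within the scatter). Compound 4 is therefore estimated at 11000 nM in this assay, with a range from 4500 nM to 27000 nM.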

Compound 4, half-maximal cytotoxic concentration: 8100 nM
Compound 4: middle estimate off by 1.4-fold (0.13 log units), on the high side; the range from low to high includes it.
By their numbers in this assay, from the lowest: compounds 4 and 1 (each within the scatter of the next); then compounds 3 and 2 (each within the scatter of the next).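

At this place, on an oxygen on a saturated carbon, 3-chlorophenyl in place of 6-(methoxycarbonyl)pyridin-2-yl gives in this assay a 1.8-fold lower number from compound 1 to compound 4 (0.26 log units; within the scatter) and so does not separate the two groups, even though only the leaving group carries hydrogen-bond acceptors. Nothing measured here accounts for the size of this step. On these data alone, whether a carboxylic acid or an amine in this same place would move the number beyond the scatter remains open. As far as these compounds go, it also remains open whether this change would read alike on another core.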